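Adding a hydroxy group to compound 1

The source may report more compounds than this note shows. Statements on the series, on what has been measured and on what is new or still open speak of the compounds shown alone.

Within the data shown here, in a functional assay on TK-10 cells (Homo sapiens) for inhibition (on this read-out lower numbers stand for stronger inhibition of growth and higher numbers for weaker inhibition of growth), compound 1 (`COc1ccc(-n2cnnc2-c2cc(OC)c(OC)c(OC)c2)cc1`) gives 9770 nM, the higher of the two numbers so far, while compound 2 (`COc1cc(-c2nncn2-c2ccc(N(C)C)cc2)cc(OC)c1OC`) gives 1660 nM. Compound 3 (`COc1ccc(-n2cnnc2-c2cc(OC)c(OC)c(OC)c2)cc1O`) has not been measured and carries hydroxy in place of hydrogen on an aromatic carbon, ortho to a methoxy group: hydroxy in place of hydrogen on an aromatic carbon. Among the measured compounds shown here, the only measured step, a 5.9-fold lower number from compound 1 to compound 2 (0.77 log units; beyond the scatter), replaced that methoxy group with dimethylamino. It is a different change and so only a weak guide, but it shows that a change on this ring can shift the number. A lower number of similar or larger size is therefore expected, with wide uncertainty. The expected step is a 20-fold lower number from compound 1 to compound 3 (1.29 log units; beyond the scatter). Compound 3 is estimated at 500 nM, within a range of 40 nM to 5000 nM.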

Compound 3, concentration for 50% growth inhibition: 7410 nM
For compound 3 the middle estimate is 15-fold (1.17 log units) below the measured one; measured number above the stated range.
By their numbers in this assay, from the lowest: compound 2; then compounds 3 and 1 (each within the scatter of the next).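

Hydroxy on an aromatic carbon, ortho to a methoxy group, gives a 1.3-fold lower number from compound 1 to compound 3 (0.12 log units; within the scatter) in this assay and so leaves the two numbers within the scatter of each other. Here, unlike the replacement of methoxy by dimethylamino with its a 5.9-fold lower number from compound 1 to compound 2 (0.77 log units; beyond the scatter) on the same ring, the change gives no readable difference. Nothing measured here offers an explanation for this result. Still open, going by these compounds, is whether an amine or a carboxylic acid at this place would move the number, and whether a longer chain such as ethoxy would do so.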